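Chloro in place of nitro on the shared core

A few compounds are considered here, and "the series" means these few. Any claim that something is new, unique, unknown or untested is made for them only; others in the source may bear on it.

Measured so far in a functional assay on HepG2 cells (Homo sapiens) for inhibition, read by MTT assay, with a stated time of 72 h; on this read-out lower numbers stand for stronger inhibition and higher numbers for weaker inhibition:
compound 1 `COc1cc(OC)c(C(=O)/C=C/c2ccc(O)cc2)c(OC)c1`: 37000 nM
compound 2 `COc1cc(OC)c(C(=O)/C=C/c2ccc(O)c(O)c2)c(OC)c1`: 27500 nM
compound 3 `COc1cc(OC)c(C(=O)/C=C/c2ccc([N+](=O)[O-])cc2)c(OC)c1`: 9400 nM

Of the three, compound 3 gives the lowest number, at 9400 nM. The next compound to consider is compound 4 `COc1cc(OC)c(C(=O)/C=C/c2ccc(Cl)cc2)c(OC)c1`, with chloro in place of nitro on an aromatic carbon.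

For the measured compounds named here, two measured steps bear on this change. The closer one is a 3.9-fold lower number from compound 1 to compound 3 (0.60 log units; beyond the scatter), which puts nitro in place of hydroxy on an aromatic carbon. This step is modest but lies beyond the scatter. The other is a 1.3-fold lower number from compound 1 to compound 2 (0.13 log units; within the scatter), which adds a hydroxy and stays within the scatter, so it offers little guidance. Going by the values given here, no measured compound carries chloro, which leaves the size of the new step uncertain.

In this assay, a small move towards a higher number is expected, possibly no larger than the scatter. The expected step is a 1.5-fold higher number from compound 3 to compound 4 (0.17 log units; within the scatter). For compound 4 the estimated value is 14000 nM, with an expected range of 6000 nM to 32000 nM.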

Compound 4, half-maximal inhibitory concentration: 12400 nM
Compound 4: the middle estimate sits 1.1-fold (0.05 log units) above what was measured, and the stated range covers the measured number.
By their numbers in this assay, from the lowest: compounds 3 and 4 (each within the scatter of the next); then compounds 2 and 1 (each within the scatter of the next).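

In this assay, chloro with 1 heavy atom and 0 hydrogen-bond acceptors stands in for nitro with 3 heavy atoms and 2 hydrogen-bond acceptors at this position, para to a large group, and the result is a 1.3-fold higher number from compound 3 to compound 4 (0.12 log units; within the scatter). The low number in this small set is therefore not unique to nitro: chloro in place of hydroxy gives a 3.0-fold lower number from compound 1 to compound 4 (0.47 log units; beyond the scatter), and 4-chlorophenyl in place of 3,4-dihydroxyphenyl gives a 2.2-fold lower number from compound 2 to compound 4 (0.35 log units; beyond the scatter). No evidence is available on what underlies these steps.

On these data alone, it remains open whether other halogens such as fluoro or bromo would fall close to chloro at this position. An amine or a carboxylic acid here is also untested in the compounds shown, so the range of groups that this position tolerates is still undefined.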